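The compounds below may be only part of what the source reports. "The series", "measured", "known", "first", "only" and "open" are said of these compounds alone.

In a functional assay on CCRF-CEM cells (Homo sapiens), read by MTT assay, with a stated time of 72 h (a higher number here means a weaker inhibitor, a lower number a stronger inhibitor), three compounds have been measured so far. Compound 1, `COc1ncnc2c1c(-c1cc3ccccc3o1)cn2[C@@H]1O[C@H](CO)[C@@H](O)[C@H]1O`, which carries 1-benzofuran-2-yl, gives 5370 nM. Compound 2, `C#Cc1cn([C@@H]2O[C@H](CO)[C@@H](O)[C@H]2O)c2ncnc(OC)c12`, which carries ethynyl at the same carbon, is reported only as a limit of the assay, > 20000 nM. The change between them is an at least 3.7-fold higher number from compound 1 to compound 2 (0.57 log units; beyond the scatter). Compound 3, `CSc1ncnc2c1c(-c1ccoc1)cn2[C@@H]1O[C@H](CO)[C@@H](O)[C@H]1O`, which carries furan-3-yl, gives 14200 nM. That is the higher of the two actual numbers, and its gap to compound 1 at 5370 nM lies beyond the scatter.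

Compound 4, `CSc1ncnc2c1c(-c1ccccc1)cn2[C@@H]1O[C@H](CO)[C@@H](O)[C@H]1O`, has not yet been measured in this assay. It differs from compound 3 by one exchange: phenyl in place of furan-3-yl on an aromatic carbon. Among the measured compounds shown here, the only measured step at this carbon is an at least 3.7-fold higher number from compound 1 to compound 2 (0.57 log units; beyond the scatter), and it offers limited guidance. That step replaces an aromatic group with ethynyl, whereas here one single aromatic ring replaces another, and the two pairs also differ elsewhere on the shared core. For the measured compounds named here, with no closer precedent, no shift beyond the scatter is expected in this assay. The expected change is a 1.1-fold lower number from compound 3 to compound 4 (0.04 log units; within the scatter). The estimated value for compound 4 is 13000 nM, with an expected range from 5000 nM to 20000 nM.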

Compound 4, half-maximal inhibitory concentration: > 20000 nM
Compound 4: only a limit was reported (the forecaster's own chance of this, stated with the estimate: 30%); at least 1.5-fold (0.18 log units) between middle value and limit.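

In this assay, compound 4 is reported only as a limit, > 20000 nM. Phenyl in place of furan-3-yl on this aromatic carbon gives an at least 1.4-fold higher number from compound 3 to compound 4 (0.14 log units; that floor lies within the scatter). This is the first step shown at this carbon in which one single aromatic ring replaces another, and it shows that the six-membered ring of carbon only, which has no hydrogen-bond acceptor, brings no lower number than the five-membered ring with its oxygen. Only the floor of this step is known, and that floor is set by the top of the measurable range: the limit of > 20000 nM in this assay, at which 2 of the 4 values shown sit.

On these data alone, how far compound 4 really lies from compound 3 stays unknown, so the data cannot say whether this exchange moves the number beyond the scatter at all. The compounds shown also leave open how this carbon would respond to a group of another kind, such as an amine, a carboxylic acid or a longer alkyl chain, or to a phenyl ring that carries one of these.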